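This account rests on a few compounds, and the source may have more. Where it says the series, first, only, none or still open, it means among the compounds named here.

Working notes on the series

Compound 1 `COc1cc(/C=C/C(=O)c2cccc(-n3cc(-c4ccccc4)[nH]c3=O)c2)ccc1O` gives 2020 nM in a functional assay on NCI-H23 cells (Homo sapiens) for inhibition; a higher number here means a weaker inhibitor of growth, a lower number a stronger inhibitor of growth. Its number is the highest of the three measured, but the gaps to compound 3 and to compound 2 are both within the scatter, so no order among the three can be read. Compound 3 `COc1cc(/C=C/C(=O)c2cccc(-n3cc(-c4cc(OC)c(OC)c(OC)c4)[nH]c3=O)c2)cc(OC)c1OC` gives 2000 nM in this assay. Compound 2 `COc1ccc(-c2cn(-c3cccc(C(=O)/C=C/c4cc(OC)c(OC)c(OC)c4)c3)c(=O)[nH]2)cc1` gives 1630 nM in this assay. Within the data shown here, the one measured step that changes a single place, a 1.2-fold higher number from compound 2 to compound 3 (0.09 log units; within the scatter), swaps the aryl group hanging from the shared core and moves nothing beyond the scatter.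

Compound 4 `COc1cc(/C=C/C(=O)c2cccc(-n3cc(-c4ccc(Cl)cc4)[nH]c3=O)c2)ccc1O` differs from compound 1 by chloro in place of hydrogen on an aromatic carbon. Among the measured compounds shown here, no measured step introduces a halogen, so nothing here bears directly on a chloro entering. For the measured compounds named here, the only comparable step touches the same aryl group in compound 2 and compound 3, and its size is within the scatter, which gives no ground for a step of any direction in this assay. Compound 4 is therefore expected to stay close to compound 1, with an estimated step of a 1.0-fold lower number from compound 1 to compound 4 (0.00 log units; within the scatter) in this assay. The estimate for compound 4 in this assay is 2000 nM, with a range from 1000 nM to 4000 nM.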

Compound 4, concentration for 50% growth inhibition: 3180 nM
For compound 4 the middle estimate is 1.6-fold (0.20 log units) below the measured one, and the stated range covers the measured number.
By their numbers in this assay, from the lowest: compounds 2, 3, 1 and 4 (each within the scatter of the next).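

Chloro in place of hydrogen, para to a large group on a six-membered aromatic ring of carbon only, gives a 1.6-fold higher number from compound 1 to compound 4 (0.20 log units; within the scatter) in this assay, the first step shown that puts a halogen on this aryl group and the first that starts from an unsubstituted phenyl. With a 1.2-fold higher number from compound 2 to compound 3 (0.09 log units; within the scatter) on the same aryl group, the series now has two single-place changes there, a chloro entering and methoxy groups being added, and neither carries the number beyond the scatter, so this position has so far shown no measurable sensitivity in this assay to either change. Nothing available explains the size of the chloro step or tells whether it has any real direction.

On these data alone, whether an amine, a carboxylic acid or a longer chain in place of the same hydrogen would move the number beyond the scatter remains open, as the four compounds cover only chloro and methoxy substituents on this aryl group. As far as these compounds go, the chloro step also rests on a single pair, so whether phenyl to 4-chlorophenyl would give a similar step with the other substituted ring of compound 2 stays open.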